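This account rests on a few compounds, and the source may have more. Where it says the series, first, only, none or still open, it means among the compounds named here.

Measured compounds:
- compound 1 `COc1cccc(Sc2c(NS(=O)(=O)c3ccc(C(C)(C)C)cc3)noc2C)c1`: 300 nM
- compound 2 `COc1cccc(Sc2c(NS(=O)(=O)c3ccc(C(C)(C)C)cc3)noc2CO)c1`: 560 nM

In an assay on COS-7 cells for displacement of a labelled ligand from Endothelin receptor type B (Sus scrofa) (on this read-out higher numbers stand for weaker inhibition and lower numbers for stronger inhibition), compound 1 gives 300 nM, and compound 2 gives 560 nM in this assay. Of the two numbers, that of compound 1 is the lower one, but the step of a 1.9-fold higher number from compound 1 to compound 2 (0.27 log units; within the scatter) lies within the scatter, so the two compounds cannot be told apart on this read-out.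

Compound 3 `Cc1onc(NS(=O)(=O)c2ccc(C(C)(C)C)cc2)c1I` differs from compound 1 by iodo in place of (3-methoxyphenyl)sulfanyl on an aromatic carbon. For the measured compounds named here, the single measured step, a 1.9-fold higher number from compound 1 to compound 2 (0.27 log units; within the scatter), concerns a hydroxy for hydrogen on the saturated chain carbon and says nothing about exchanging the (3-methoxyphenyl)sulfanyl group for iodo; no measured pair bears on that change. The group that leaves is large and the group that enters is a single atom, and the shared core keeps its sulfonamide and methyl unchanged. Going by the values given here, with no comparable step to lean on, the expectation for compound 3 rests on the size of the change alone: a higher number than compound 1 is expected, the step of a 5.0-fold higher number from compound 1 to compound 3 (0.70 log units; beyond the scatter) being a guess with a wide range. Compound 3 is therefore expected to give about 1500 nM in this assay, within 300 nM to 8000 nM.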

Compound 3, half-maximal inhibitory concentration: 30000 nM
Compound 3: the middle estimate sits 20-fold (1.30 log units) below what was measured; measured number above the stated range.
By their numbers in this assay, from the lowest: compounds 1 and 2 (each within the scatter of the next); then compound 3.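

In this assay, the exchange of (3-methoxyphenyl)sulfanyl for iodo on this aromatic carbon of the five-membered ring is the first change among these compounds whose step lies beyond the scatter: a 100-fold higher number from compound 1 to compound 3 (2.00 log units; beyond the scatter). For the compounds shown here, the only earlier step, a 1.9-fold higher number from compound 1 to compound 2 (0.27 log units; within the scatter), concerned the saturated chain carbon and lay within the scatter, whereas this result shows that the read-out depends strongly on what stands at this place, and that a single iodine atom does not preserve the number given by the larger group. No evidence at hand accounts for the size of this step.

The change removes the sulfur link, the six-membered aromatic ring and the methoxy group all at once, and the compounds shown do not tell which of these parts the number depends on. From the compounds shown here alone, it also stays open whether a phenyl ring bound directly to the aromatic carbon, a (3-methoxyphenyl)oxy group or a plain phenylsulfanyl group at this place would keep the number close to that of compound 1.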